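One Added Methoxy on Compound 2

The source may hold more compounds than are shown below. What is called first, only, known or untested is meant among the compounds shown, and "the series" means these compounds.

Among the measured compounds shown here, in a functional assay on THP-1 cells (Homo sapiens) for cytotoxicity, read by MTT assay, with a stated time of 24 h (on this read-out lower numbers stand for stronger inhibition and higher numbers for weaker inhibition), compound 2 (`COc1cc(/C=C2\CN(C)C/C(=C\c3ccc(Br)cc3)C2=O)cc(OC)c1`) gives 4270 nM and holds the highest of the three numbers measured so far. Compound 3 (`COc1cc(/C=C2\CN(C)C/C(=C\c3cccc([N+](=O)[O-])c3)C2=O)cc(OC)c1`) gives 1770 nM in the same test. Compound 1 (`COc1cc(/C=C2\CN(C)C/C(=C\c3ccccc3F)C2=O)cc(OC)c1OC`) gives 640 nM and is also lower than compound 2 by more than the scatter.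

Compound 4 (`COc1cc(/C=C2\CN(C)C/C(=C\c3ccc(Br)cc3)C2=O)cc(OC)c1OC`) has not yet been measured. It differs from compound 2 by a single change (methoxy in place of hydrogen on an aromatic carbon): methoxy in place of hydrogen on an aromatic carbon, ortho to two methoxy groups and para to a large group.

For the measured compounds named here, the one measured single change is a 2.4-fold lower number from compound 2 to compound 3 (0.38 log units; beyond the scatter) and swaps 4-bromophenyl for 3-nitrophenyl. It shows a modest step, but it does not test the methoxy. Compound 1 already carries this methoxy and gives 640 nM with a different second aromatic ring as well, so its gap to compound 2 cannot be credited to the methoxy alone.

A modest move towards a lower number therefore seems likely, and the expected step is a 2.5-fold lower number from compound 2 to compound 4 (0.40 log units; beyond the scatter) in this assay with real uncertainty. For compound 4 the estimated value is 1700 nM (expected range 600 nM to 4500 nM).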

Compound 4, half-maximal inhibitory concentration: 5330 nM
Compound 4: middle estimate off by 3.1-fold (0.50 log units), on the low side; measured number outside the range, above it.
By their numbers in this assay, from the lowest: compound 1; then compound 3; then compounds 2 and 4 (each within the scatter of the next).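

In this assay, putting a methoxy on the aromatic carbon ortho to two methoxy groups and para to a large group does not shift the result beyond the usual scatter (a 1.2-fold higher number from compound 2 to compound 4 (0.10 log units; within the scatter)), so on this 4-bromophenyl background the added group leaves no readable mark. With that methoxy present on both compounds, changing only the second aromatic ring has a much clearer effect (an 8.3-fold higher number from compound 1 to compound 4 (0.92 log units; beyond the scatter)), with 4-bromophenyl in place of 2-fluorophenyl. The gap that could not be credited to the methoxy before can now be placed with that ring swap, and no measurement at hand explains either result.

From the compounds shown here alone, it remains open whether the methoxy would count for as little alongside the other second rings, the 3-nitrophenyl and the 2-fluorophenyl, since the one clean test of it uses 4-bromophenyl. The compounds shown also leave open how this same aromatic carbon would respond to a different group, such as a hydroxyl, an amine or a longer chain like butoxy, in place of the methoxy.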